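Methylsulfonyl in place of hydroxy on compound 2

The source may hold more compounds than are shown below. What is called first, only, known or untested is meant among the compounds shown, and "the series" means these compounds.

Measured so far in an ADME assay on microsomes from liver (Rattus norvegicus) for metabolic stability, read by LC-MS, with a stated time of 30 min, tested at 0.5 uM; a higher number here means that more of the compound is left, a lower number that less of the compound is left:
- compound 1 `c1ccc(-c2nc(-c3csc(N=C4NCCCN4)n3)cs2)cc1`: 31%
- compound 2 `Oc1ccc(-c2nc(-c3csc(N=C4NCCCN4)n3)cs2)cc1`: 53%
- compound 3 `c1cc(-c2nc(-c3csc(N=C4NCCCN4)n3)cs2)ccn1`: 9%

Compound 2 holds the highest of the three numbers. The steps that set it apart are a number 22 percentage points higher from compound 1 to compound 2 (beyond the scatter) and a number 44 percentage points lower from compound 2 to compound 3 (beyond the scatter).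

The next structure is compound 4 `CS(=O)(=O)c1ccc(-c2nc(-c3csc(N=C4NCCCN4)n3)cs2)cc1`, which carries methylsulfonyl in place of hydroxy on an aromatic carbon, para to a large group (methylsulfonyl in place of hydroxy on an aromatic carbon).

Going by the values given here, no measured compound carries methylsulfonyl, so the evidence is indirect. Hydroxy leaves in this change, and the closest measured step for hydroxy is a number 22 percentage points higher from compound 1 to compound 2 (beyond the scatter), a modest one. Removing hydroxy alone might therefore give back some of that gain, but the entering group is not the hydrogen of compound 1. The other measured change at this position of the series, a number 22 percentage points lower from compound 1 to compound 3 (beyond the scatter), is also modest, while a number 44 percentage points lower from compound 2 to compound 3 (beyond the scatter) shows that a large drop from compound 2 is possible. A modest downward step in this assay is therefore expected, with wide uncertainty in both directions. The expected step is a number 13 percentage points lower from compound 2 to compound 4 (beyond the scatter). For compound 4 the estimated value is 40%, with an expected range from 15% to 70%.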

Compound 4, percent of the compound remaining: 53%
The estimate for compound 4 lay 13 percentage points below the measured number; the measured number falls inside the stated range.
By their numbers in this assay, from the lowest: compound 3; then compound 1; then compounds 2 and 4 (each within the scatter of the next).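

In this assay, the exchange of hydroxy for methylsulfonyl at this place on the aromatic ring gives no change at the digits printed from compound 2 to compound 4 (within the scatter), so the two groups cannot be told apart by this read-out, although the entering group has more heavy atoms and no hydrogen-bond donor. Set against the unsubstituted phenyl, methylsulfonyl gives a number 22 percentage points higher from compound 1 to compound 4 (beyond the scatter), which matches a number 22 percentage points higher from compound 1 to compound 2 (beyond the scatter); the higher number at this place therefore does not need a hydrogen-bond donor, at least in these two compounds, while compound 3, with its pyridin-4-yl ring, stands apart as a change of the ring itself rather than of a group on it. The data at hand offer no explanation for why these two different groups give the same number.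

Two compounds cannot show whether almost any group in place of hydrogen at this place gives the same number or whether hydroxy and methylsulfonyl share something specific, and an amine, a carboxylic acid or a methoxy group there would help separate those readings. From the compounds shown here alone, whether any group at this place can carry the number beyond that of compound 2 and compound 4 also remains open.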